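Benzoyl in Place of 4-Cyanobenzyl: A Weaker Cytotoxic Compound Expected

The source may hold more compounds than are shown below. What is called first, only, known or untested is meant among the compounds shown, and "the series" means these compounds.

Compound 1 `N#Cc1ccc(CN2CCC(NC(=O)COc3ccc(-c4cc(=O)c5ccccc5o4)cc3)CC2)cc1` gives 6700 nM in a functional assay on HepG2 cells (Homo sapiens) for cytotoxicity, read by MTT assay, with a stated time of 72 h; a lower number here means a stronger inhibitor, a higher number a weaker inhibitor.
Compound 2 `N#Cc1ccc(CN2CCC(NC(=O)COc3ccc4c(=O)cc(-c5ccccc5)oc4c3)CC2)cc1` gives 9300 nM in this assay.
Compound 3 `O=C(COc1ccc2c(=O)cc(-c3ccccc3)oc2c1)NC1CCN(C(=O)c2ccccc2)CC1` reaches only a limit of the assay, > 20000 nM in this assay.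

Compound 1 and compound 2 contain the same atoms joined differently; the difference between the two cores is not broken down here. Their two numbers sit within the usual scatter of each other. The change benzoyl in place of 4-cyanobenzyl on an amine nitrogen in a ring gave an at least 2.1-fold higher number from compound 2 to compound 3 (0.33 log units; beyond the scatter), the second compound sitting at the limit of > 20000 nM in this assay, at which 1 of the 3 values shown sits.

Compound 4 `O=C(COc1ccc(-c2cc(=O)c3ccccc3o2)cc1)NC1CCN(C(=O)c2ccccc2)CC1` carries the same change as compound 3, here (benzoyl in place of 4-cyanobenzyl on an amine nitrogen in a ring). Because compound 3 showed an at least 2.1-fold higher number from compound 2 to compound 3 (0.33 log units; beyond the scatter), a step of similar size is expected from compound 1, namely a 3.0-fold higher number from compound 1 to compound 4 (0.47 log units; beyond the scatter). Compound 4 is therefore estimated to give about 20000 nM, expected to fall between 8000 nM and 60000 nM, most probably again reported only as a limit.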

Compound 4, half-maximal inhibitory concentration: > 20000 nM
Compound 4 ended at the assay's limit; the forecaster's own chance of this, stated with the estimate: 65%; the middle value sits exactly at the limit.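

In this assay, benzoyl in place of 4-cyanobenzyl on an amine nitrogen in a ring gave an at least 2.9-fold higher number from compound 1 to compound 4 (0.47 log units; beyond the scatter), so the change went the same way on both cores shown. Two cores show only that this direction held here, not that it would hold on any further core. The values of compound 3 and compound 4 are limits of the assay and not numbers, so the two steps cannot be compared in size: the same change on two cores in this assay, an at least 2.1-fold higher number (0.33 log units; beyond the scatter) from compound 2 to compound 3 and an at least 2.9-fold higher number (0.47 log units; beyond the scatter) from compound 1 to compound 4; the limit leaves it open whether they differ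

Going by these compounds, it remains open how large either step really is. On these data alone, it is also open whether the nitrile or the carbonyl accounts for the change, a question that a plain benzyl group on the same nitrogen could help to separate.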